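The source may hold more compounds than are shown below. What is called first, only, known or untested is meant among the compounds shown, and "the series" means these compounds.

Measured so far:
compound 1 `O=C(CSc1nnc(-c2ccncc2)o1)N/N=C/c1ccc(F)cc1`: 13500 nM
compound 2 `O=C(CSc1nnc(-c2ccncc2)o1)N/N=C/c1ccc(O)cc1`: 11700 nM

Both compounds share the same core and differ only in the group on the carbon with a double bond to nitrogen. In a functional assay on MCF7 cells (Homo sapiens) for cytotoxicity, read by MTT assay, with a stated time of 48 h (a higher number here means a weaker inhibitor, a lower number a stronger inhibitor), compound 1 gives 13500 nM and compound 2 gives 11700 nM. Among the compounds with values here, the one step between them, a 1.2-fold lower number from compound 1 to compound 2 (0.06 log units; within the scatter), leaves compound 2 at the lower of the two numbers, but within the scatter of compound 1, so no order can be read from the pair.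

Compound 3 `O=C(CSc1nnc(-c2ccncc2)o1)N/N=C/c1ccccc1[N+](=O)[O-]` is the next member: 2-nitrophenyl in place of 4-hydroxyphenyl on a carbon with a double bond to nitrogen. Within the data shown here, no measured step involves a 2-nitrophenyl group, so the only step at hand is the hydroxy-for-fluoro exchange, which stayed within the scatter. On that basis no shift beyond the scatter is expected in this assay for compound 3, and the step of a 1.0-fold higher number from compound 2 to compound 3 (0.01 log units; within the scatter) is estimated as flat. The value for compound 3 is expected at 12000 nM, within the range 5000 nM to 30000 nM.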

Compound 3, half-maximal inhibitory concentration: 35600 nM
Compound 3: the middle estimate sits 3.0-fold (0.47 log units) below what was measured; measured number outside the range, above it.
By their numbers in this assay, from the lowest: compounds 2 and 1 (each within the scatter of the next); then compound 3.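

In this assay, the group on the carbon with a double bond to nitrogen does shift the number, which the hydroxy-for-fluoro exchange alone did not show: 2-nitrophenyl in place of 4-hydroxyphenyl gives a modest step beyond the scatter (a 3.0-fold higher number from compound 2 to compound 3 (0.48 log units; beyond the scatter)), and 2-nitrophenyl in place of 4-fluorophenyl gives another (a 2.6-fold higher number from compound 1 to compound 3 (0.42 log units; beyond the scatter)). Compound 3 is therefore the weakest of the three, so this position is not indifferent to the aryl group it carries. No measured evidence bears on what lies behind this shift.

The compounds shown leave open whether the nitro group itself or its placement on the ring accounts for the step. Also open, from the compounds shown here alone, is how a phenyl ring carrying an amine or a carboxylic acid would read in this assay.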